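Cyclohexyl Gives Way to a Trifluoromethylcyclopropyl Group

The compounds below may be only part of what the source reports. "The series", "measured", "known", "first", "only" and "open" are said of these compounds alone.

Measured compounds:
compound 1 `Cn1nc(CN2CCCC2)nc1-c1ccc(C2CCCCC2)cc1`: 20 nM
compound 2 `CC(C)n1nc(CN2CCCC2)nc1-c1ccc(C(C)(C)C)cc1`: 2.2 nM

Both were tested in an assay on membranes from Jurkat cells for displacement of a labelled ligand from Sigma non-opioid intracellular receptor 1 (Homo sapiens), read by scintillation counting, with a stated time of 2 h; on this read-out higher numbers stand for weaker inhibition and lower numbers for stronger inhibition. Of the two numbers, compound 1 holds the higher one; compound 2 sits at a lower number, and the gap between them lies well beyond the usual scatter. Going by the values given here, compound 2 differs from compound 1 in more than one place, so no single step connects the two measurements.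

Compound 3 `Cn1nc(CN2CCCC2)nc1-c1ccc(C2(C(F)(F)F)CC2)cc1` keeps the shared core of compound 1 and alters one group: 1-(trifluoromethyl)cyclopropyl in place of cyclohexyl on an aromatic carbon. Among the compounds with values here, no measured pair shows this exchange, so any expectation rests on compound 1 alone and carries wide uncertainty. A small step toward a weaker number, or none beyond the scatter, is expected; the expected step is a 2.0-fold higher number from compound 1 to compound 3 (0.30 log units; within the scatter). Compound 3 is accordingly estimated at 40 nM, with a range from 10 nM to 160 nM.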

Compound 3, inhibition constant: 9.9 nM
Beside the measured number, compound 3's estimate is 4.0-fold (0.61 log units) above it; measured number outside the range, below it.
By their numbers in this assay, from the lowest: compound 2; then compound 3; then compound 1.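

In this assay, exchanging cyclohexyl for 1-(trifluoromethyl)cyclopropyl, para to a large group, gives a 2.0-fold lower number from compound 1 to compound 3 (0.31 log units; beyond the scatter), a modest step. This is the first single-place comparison among the compounds shown, and it indicates that this position tolerates a three-membered ring bearing trifluoromethyl in place of a six-membered ring with no loss on this read-out. Nothing available explains why the number falls.

The compounds shown leave open how a plain cyclopropyl or a 1-methylcyclopropyl group would compare at the same place, so the contributions of the small ring and the trifluoromethyl group cannot be separated. Compound 2 differs from compound 1 and compound 3 in more than one place, so neither pair can be read as a step.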